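Swapping acetoxy for sulfanyl in a paw-edema series

A few compounds are considered here, and "the series" means these few. Any claim that something is new, unique, unknown or untested is made for them only; others in the source may bear on it.

Measured compounds:
compound 1 `O=C(O)c1ccc(-n2c(-c3ccccc3)cc3c2CCCC3)cc1O` gives 0%
compound 2 `CC(=O)Oc1ccc(-n2c(-c3ccccc3)cc3c2CCCC3)cc1C(=O)O` gives 50%
compound 3 `COC(=O)c1cc(-n2c(-c3ccccc3)cc3c2CCCC3)ccc1O` gives 0%

These three compounds share one core and were tested in a functional assay on the whole organism (strain Wistar) for inhibition, with Rattus norvegicus as the target, read by paw edema, with stated times of 30 min and 3 h, at a dose of 200 mg/kg by the oral route; a higher number here means more inhibition at the dose given (going by the name of the read-out), a lower number less inhibition. Compound 2 stands highest of the three numbers. Compound 1 and compound 3 both sit at the same level, each a number below compound 2 by a gap beyond the scatter of this kind of measurement. Compound 2 is the only one that carries an acetoxy group ortho to its carboxy group; compound 1 carries a hydroxy group there instead, and compound 3 carries a hydroxy group with the acid masked as a methyl ester.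

The next compound, compound 4 `O=C(O)c1cc(-n2c(-c3ccccc3)cc3c2CCCC3)ccc1S`, again differs from compound 2 in that one spot: sulfanyl in place of acetoxy on an aromatic carbon. Sulfanyl in place of acetoxy on an aromatic carbon leaves the carboxy group intact but removes the only feature that set compound 2 apart from the two compounds with the lower numbers.

Within the data shown here, no direct step between measured compounds is available, so the expectation rests on the pattern that compound 1 and compound 3, lacking acetoxy, both give no inhibition. Compound 4 is therefore expected to fall well back toward that level, a downward step a number 35 percentage points lower from compound 2 to compound 4 (beyond the scatter) in this assay. Compound 4 is estimated at 15%, with a likely range from 0% to 40%.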

Compound 4, a percentage reported as inhibition, in the whole organism at one dose (the size of the read-out at that dose, not a potency): 50%
For compound 4 the middle estimate is 35 percentage points below the measured one; the whole stated range lies below it.
By their numbers in this assay, from the lowest: compounds 1 and 3 (each within the scatter of the next); then compounds 2 and 4 (each within the scatter of the next).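

In this assay, placing sulfanyl instead of acetoxy on this aromatic carbon, ortho to a carboxy group, gives no change at the digits printed from compound 2 to compound 4 (within the scatter), so the two groups cannot be told apart at this dose. This shows that an intact acetoxy group is not needed at this position for a reading at this level, since the much smaller sulfanyl group does as well. Nothing available explains why these two different groups read alike.

The compounds shown leave open whether an amine or a methoxy group on the same carbon would also hold this level. They also leave open whether sulfanyl and acetoxy would still match at lower doses, given that a single-dose percentage is not a measure of potency.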